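The source may hold more compounds than are shown below. What is called first, only, known or untested is meant among the compounds shown, and "the series" means these compounds.

Measured compounds:
compound 1 `O=C(Nc1cccc(-c2oc3cc(-c4ccc(F)cc4)ccc3c(=O)c2O)c1)c1ccccc1F`, 10100 nM
compound 2 `Cc1cccc(C(=O)Nc2cccc(-c3oc4cc(-c5ccc(F)cc5)ccc4c(=O)c3O)c2)c1`, 13500 nM
compound 3 `CCc1ccc(C(=O)Nc2cccc(-c3oc4cc(-c5ccc(F)cc5)ccc4c(=O)c3O)c2)cc1`, 20600 nM

In a functional assay on HepG2 cells (Homo sapiens) for antiproliferative activity, read by CCK-8 assay, with a stated time of 72 h (on this read-out lower numbers stand for stronger inhibition and higher numbers for weaker inhibition), compound 3 stands at the highest number of the measured set; compound 2 lies nearest and within the scatter of it, compound 1 furthest, beyond the scatter. Compound 4 `Cc1cc(C)cc(C(=O)Nc2cccc(-c3oc4cc(-c5ccc(F)cc5)ccc4c(=O)c3O)c2)c1` differs from compound 3 by 3,5-dimethylphenyl in place of 4-ethylphenyl on a carbonyl carbon. Going by the values given here, every measured step so far changes the aryl group on this same carbonyl carbon: a 1.3-fold higher number from compound 1 to compound 2 (0.13 log units; within the scatter), a 2.0-fold higher number from compound 1 to compound 3 (0.31 log units; beyond the scatter), a 1.5-fold higher number from compound 2 to compound 3 (0.18 log units; within the scatter). All are small, only one beyond the scatter. Since compound 2, carrying 3-methylphenyl, sits within the scatter of compound 3, little movement is expected from the 3,5-dimethylphenyl; the expected step is a 1.3-fold lower number from compound 3 to compound 4 (0.11 log units; within the scatter), so no change beyond the scatter. Compound 4 is estimated at 16000 nM, range 8000 nM to 32000 nM.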

Compound 4, half-maximal inhibitory concentration: 13400 nM
The estimate for compound 4 lay 1.2-fold (0.08 log units) above the measured number; the measured number falls inside the stated range.
By their numbers in this assay, from the lowest: compounds 1, 4, 2 and 3 (each within the scatter of the next, the first and the last beyond it).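

In this assay the methyl in place of hydrogen on an aromatic carbon gives (a 1.0-fold lower number from compound 2 to compound 4 (0.00 log units; within the scatter)), so this added methyl on the aryl group at the carbonyl carbon produces no step beyond the scatter. The two other new steps, (a 1.5-fold lower number from compound 3 to compound 4 (0.19 log units; within the scatter)) and (a 1.3-fold higher number from compound 1 to compound 4 (0.12 log units; within the scatter)), also stay within the scatter, so 3,5-dimethylphenyl is not separated from 4-ethylphenyl, 3-methylphenyl or 2-fluorophenyl here. No supporting data bear on these numbers.

As far as these compounds go, whether an amine, a carboxylic acid or a longer chain on this aryl group would move the number beyond the scatter remains open.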